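The source may report more compounds than this note shows. Statements on the series, on what has been measured and on what is new or still open speak of the compounds shown alone.

Measured in a functional assay on SGC-7901 cells (Homo sapiens) for antiproliferative activity, read by MTT assay, with a stated time of 24 h; a higher number here means a weaker inhibitor, a lower number a stronger inhibitor:
- compound 1 `O=C(NNc1ccccc1Cl)c1ccc(NS(=O)(=O)c2cnc(O)nc2O)cc1`: 3630 nM
- compound 2 `CCCCOc1ccc(C(=O)NNC(=O)c2ccc(NS(=O)(=O)c3cnc(O)nc3O)cc2)cc1`: 14700 nM
- compound 3 `Cc1ccc(C(=O)NNC(=O)c2ccc(NS(=O)(=O)c3cnc(O)nc3O)cc2)cc1`: > 20000 nM (a limit of the assay, not a number)

As far as these compounds go, compound 3 stands only at the limit of > 20000 nM in this assay, at which 1 of the 3 values shown sits, so its true position is unknown. Compound 4 `O=C(NNC(=O)c1cccc(Cl)c1)c1ccc(NS(=O)(=O)c2cnc(O)nc2O)cc1` carries 3-chlorophenyl in place of 4-methylphenyl on a carbonyl carbon.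

Going by the values given here, no measured step makes this exact exchange, so the two available steps bear on it only indirectly. The first, an at least 5.5-fold higher number from compound 1 to compound 3 (0.74 log units; beyond the scatter), puts (4-methylphenyl)carbonyl in place of 2-chlorophenyl on an amine nitrogen, so it changes more than the aryl group. The second, an at least 1.3-fold higher number from compound 2 to compound 3 (0.13 log units; that floor lies within the scatter), puts methyl in place of butoxy on an aromatic carbon, and it is the closer structural precedent. Its size is bounded only by a floor.

Among the compounds with values here, compound 1, the one chlorinated compound measured so far, gives 3630 nM, but it lacks the second carbonyl that compound 4 keeps. Compound 2, which keeps that carbonyl, gives 14700 nM. On these two values, a modest move towards a lower number is expected in this assay, and a result reported only as a limit remains quite possible. The estimated step is an at least 1.6-fold lower number from compound 3 to compound 4 (0.22 log units; that floor lies within the scatter). For compound 4 the expected value is 12000 nM, with an estimated range of 4000 nM to 30000 nM.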

Compound 4, half-maximal inhibitory concentration: 8610 nM
Beside the measured number, compound 4's estimate is 1.4-fold (0.14 log units) above it, within the range that was stated.
By their numbers in this assay, from the lowest: compound 1; then compounds 4 and 2 (each within the scatter of the next). At a limit, above all of these: compound 3.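

In this assay, going by these compounds alone, 3-chlorophenyl in place of 4-methylphenyl on the carbonyl carbon gives the first step at this position that clears the scatter: an at least 2.3-fold lower number from compound 3 to compound 4 (0.36 log units; beyond the scatter). Compound 3 is held only at a limit of the assay, so the size of that step is a floor and not a measured distance: the limit of > 20000 nM in this assay, at which 1 of the 4 values shown sits.

The other two steps place this aryl group more closely: 3-chlorophenyl in place of 4-butoxyphenyl gives a 1.7-fold lower number from compound 2 to compound 4 (0.23 log units; within the scatter), which sets no order between those two groups, while (3-chlorophenyl)carbonyl in place of 2-chlorophenyl on the amine nitrogen gives a 2.4-fold higher number from compound 1 to compound 4 (0.38 log units; beyond the scatter), so the chlorinated aryl on the carbonyl carbon does not match the shorter arrangement in this read-out.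

The compounds shown do not separate the effect of the chlorine from that of the group's substitution pattern; a 4-chlorophenyl or a 3-methylphenyl group on this carbonyl carbon would settle that. As far as these compounds go, how an aryl group carrying an amine or a carboxylic acid would read in this assay also remains open.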